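The source may report more compounds than this note shows. Statements on the series, on what has been measured and on what is new or still open speak of the compounds shown alone.

Of the compounds shown here, three sharing one core have been measured in a functional assay on HepG2 cells (Homo sapiens) for inhibition, read by MTT assay, with a stated time of 72 h; a higher number here means a weaker inhibitor, a lower number a stronger inhibitor. Compound 1 `CN(C(=O)NC(=O)c1ccc(F)c(F)c1)c1nc(C(F)(F)F)c(C(=O)N/N=C/c2ccc(C(F)(F)F)cc2)s1` gives 6.26 ug/mL. Compound 2 `CN(C(=O)NC(=O)c1ccc(F)c(F)c1)c1nc(C(F)(F)F)c(C(=O)N/N=C/c2ccccc2C(F)(F)F)s1` gives 10.4 ug/mL. Compound 3 `CN(C(=O)NC(=O)c1ccc(F)c(F)c1)c1nc(C(F)(F)F)c(C(=O)N/N=C/c2cccc(C(F)(F)F)c2)s1` gives 5.6 ug/mL. These three differ only in where the trifluoromethyl group sits on the phenyl ring attached to the carbon with a double bond to nitrogen, and the numbers lie close together: the step of a 1.7-fold higher number from compound 1 to compound 2 (0.22 log units; within the scatter), the step of a 1.1-fold lower number from compound 1 to compound 3 (0.05 log units; within the scatter) and the step of a 1.9-fold lower number from compound 2 to compound 3 (0.27 log units; within the scatter) all fall within the scatter, so compound 2 cannot be told apart from compound 1 or compound 3 on these numbers.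

Compound 4 `CN(C(=O)NC(=O)c1c(F)cccc1F)c1nc(C(F)(F)F)c(C(=O)N/N=C/c2ccccc2C(F)(F)F)s1` is built from compound 2 by a change at the other end of the molecule: 2,6-difluorophenyl in place of 3,4-difluorophenyl on a carbonyl carbon. Going by the values given here, no measured step touches this difluorophenyl group; every measured step moved the trifluoromethyl group on the other ring, and each of those was within the scatter. The direction of this new change is therefore unknown, and the measured steps give no reason to expect a move beyond the scatter, though they do not rule one out. The expected step is a 1.0-fold lower number from compound 2 to compound 4 (0.02 log units; within the scatter). Compound 4 is thus estimated at 10 ug/mL, with a range from 4 ug/mL to 25 ug/mL.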

Compound 4, half-maximal inhibitory concentration: 26.1 ug/mL
Compound 4: middle estimate off by 2.6-fold (0.42 log units), on the low side; measured number above the stated range.
By their numbers in this assay, from the lowest: compounds 3, 1 and 2 (each within the scatter of the next); then compound 4.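

In this assay, the difluorophenyl group on the carbonyl carbon proves able to move the number: replacing 3,4-difluorophenyl with 2,6-difluorophenyl gives a 2.5-fold higher number from compound 2 to compound 4 (0.40 log units; beyond the scatter), a modest step but the only one so far that lies beyond the scatter. Moving the trifluoromethyl group around its ring gave no step beyond the scatter, whereas this change gives a weaker inhibitor, even though the group that leaves and the group that enters have the same atoms and the same counts of donors and acceptors, so the way the two fluorines are placed on the ring is enough to matter here. No measurement on hand accounts for this step.

On these data alone, the change has been read against only one partner, 2-(trifluoromethyl)phenyl on the carbon with a double bond to nitrogen, so it remains open whether it would give a similar step with 3-(trifluoromethyl)phenyl or 4-(trifluoromethyl)phenyl in that place. The compounds shown also leave open how other groups on the carbonyl carbon would behave, such as plain phenyl, 2-fluorophenyl or 4-methoxyphenyl.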